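The source may hold more compounds than are shown below. What is called first, only, known or untested is meant among the compounds shown, and "the series" means these compounds.

Compounds measured in a functional assay on KB cells (Homo sapiens) for antiproliferative activity; on this read-out higher numbers stand for weaker inhibition and lower numbers for stronger inhibition:
- compound 1, `CSc1nc2cnsc2[nH]1`: 15000 nM.
- compound 2, `Cc1nsc2ncn([C@H]3C[C@H](O)[C@@H](CO)O3)c12`: > 100000 nM.
- compound 3, `CSc1nc2snc(C)c2n1[C@H]1C[C@H](O)[C@@H](CO)O1`: 30000 nM.

For compound 2 the figure in this assay is a limit of the assay and not a number (the limit of > 100000 nM in this assay, at which 1 of the 3 values shown sits). The only step that has been measured between two of these compounds is an at least 3.3-fold lower number from compound 2 to compound 3 (0.52 log units; beyond the scatter). The number for compound 3 is the larger of the two numbers in hand, but compound 1 is the nearest to it and the two lie within the usual scatter of each other, so no order can be read between them.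

The unmeasured compound 4, `CSc1nc2sncc2n1[C@H]1C[C@H](O)[C@@H](CO)O1`, differs from compound 3 in one place: hydrogen in place of methyl on an aromatic carbon. Among the measured compounds shown here, no measured step covers this change. For the measured compounds named here, compound 1, which also lacks the methyl, gives a number close to that of compound 3, and the only measured step concerns the methylsulfanyl instead. Compound 4 is therefore expected to give about 20000 nM in this assay, in the range 6000 nM to 70000 nM. The expected step of a 1.5-fold lower number from compound 3 to compound 4 (0.18 log units; within the scatter) is estimated to stay within the scatter.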

Compound 4, half-maximal inhibitory concentration: 6000 nM
The estimate for compound 4 lay 3.3-fold (0.52 log units) above the measured number, and the stated range covers the measured number.
By their numbers in this assay, from the lowest: compound 4; then compounds 1 and 3 (each within the scatter of the next). At a limit, above all of these: compound 2.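

In this assay, hydrogen in place of methyl on the aromatic carbon next to the ring nitrogen gives a 5.0-fold lower number from compound 3 to compound 4 (0.70 log units; beyond the scatter), a step beyond the scatter. Among the compounds shown here, the earlier measured step concerned only the methylsulfanyl, so this is the first sign that this second place on the shared core also affects the read-out, and that the methyl is not required for inhibition, since the compound with hydrogen here gives the lower number. Nothing in the data shown accounts for the size or direction of this step.

From the compounds shown here alone, it remains open whether any group here other than methyl would also raise the number, for example an ethyl, a chlorine, an amine or a carboxylic acid. Going by these compounds, it is also open whether the methylsulfanyl step would hold with hydrogen at this carbon.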